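This account rests on a few compounds, and the source may have more. Where it says the series, first, only, none or still open, it means among the compounds named here.

Measured so far in a physicochemical assay for solubility, with a stated time of 18 h, at pH 7.4; on this read-out lower numbers stand for lower solubility and higher numbers for higher solubility:
compound 1 `c1ccc(Oc2ccc3c(NCCCNCc4ccco4)ccnc3c2)cc1` — 14500 nM
compound 2 `COc1cccc(CNCCCNc2ccnc3cc(Oc4ccc(Cl)cc4)ccc23)c1O` — 14500 nM

Compound 2 stands level with compound 1 in this assay; the two values lie within the usual scatter, and no order between them is read. Compound 3 `COc1cccc(CNCCCNc2ccnc3cc(Cc4cc(C)cc(C)c4)ccc23)c1O` is not yet measured. It differs from compound 2 by 3,5-dimethylbenzyl in place of 4-chlorophenoxy on an aromatic carbon. Among the measured compounds shown here, no step between measured compounds bears on this change, and the expectation rests on the change alone: a modest fall in this assay, somewhat beyond the scatter, is expected, as a 2.9-fold lower number from compound 2 to compound 3 (0.46 log units; beyond the scatter). For compound 3 the estimate in this assay is 5000 nM, with a range from 1200 nM to 20000 nM.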

Compound 3, solubility: 4200 nM
Compound 3: middle estimate off by 1.2-fold (0.08 log units), on the high side, within the range that was stated.
By their numbers in this assay, from the lowest: compound 3; then compounds 1 and 2 (each within the scatter of the next).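

In this assay, among the compounds shown here, 3,5-dimethylbenzyl in place of 4-chlorophenoxy on this aromatic carbon of the shared core gives a 3.5-fold lower number from compound 2 to compound 3 (0.54 log units; beyond the scatter) and is the only step read at this position. The number at this position therefore moves with the group it carries, though one pair sets no trend. No measured evidence ties the step to any feature of the change.

The link and the ring substituents change together in this pair, leaving their shares unresolved; 4-chlorobenzyl and 3,5-dimethylphenoxy would separate them. Going by these compounds, how an amine or a carboxylic acid at this carbon would read also remains open.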